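This account rests on a few compounds, and the source may have more. Where it says the series, first, only, none or still open, it means among the compounds named here.

Working notes on the series, in an ADME assay for pharmacokinetics; a higher number here means that the compound lasts longer, a lower number that the compound disappears faster: compound 2 `CC[C@H](c1ccc(O)cc1)[C@@H](CC)c1ccc(C(=O)CCl)cc1` stands at 0.5 h, the lower of the two numbers so far, while compound 1 `CC[C@H](c1ccc(O)cc1)[C@@H](CC)c1ccc(CBr)cc1` gives 2.5 h. The next structure, compound 3 `CC[C@H](c1ccc(O)cc1)[C@@H](CC)c1ccc(C(=O)CBr)cc1`, carries bromo in place of chloro on a saturated chain carbon bound to a carbonyl carbon, bromo in place of chloro on a saturated chain carbon bound to a carbonyl carbon. Among the compounds with values here, the only measured step nearby is a 5.0-fold lower number from compound 1 to compound 2 (0.70 log units; beyond the scatter). Within the data shown here, it puts (chloromethyl)carbonyl in place of bromomethyl, so no measured step shows the halogen change alone. No step beyond the scatter is therefore expected in this assay. Compound 3 is estimated at 0.4 h, with an expected range of 0.2 h to 0.8 h, meaning an expected 1.3-fold lower number from compound 2 to compound 3 (0.10 log units; within the scatter).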

Compound 3, half-life: < 0.5 h
Compound 3 was reported as a limit (the forecaster's own chance of this, stated with the estimate: 3%); the middle value does not contradict the limit.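

In this assay, the reading for compound 3 is a limit, < 0.5 h, not a number. Chloro to bromo on a saturated chain carbon bound to a carbonyl carbon gives a number no higher from compound 2 to compound 3 (the limit leaves the size open). Against the bromomethyl group, (bromomethyl)carbonyl gives an at least 5.0-fold lower number from compound 1 to compound 3 (0.69 log units; beyond the scatter). The low half-life therefore holds with either halogen on this chain, as with a 5.0-fold lower number from compound 1 to compound 2 (0.70 log units; beyond the scatter).

Going by these compounds, how far bromo and chloro lie apart remains open. Also open, on these data alone, is whether an amine or a hydroxyl group on that same saturated chain carbon would give a longer half-life.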